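Sulfonylpiperidine series: replacing the biaryl on the sulfonamide

This account rests on a few compounds, and the source may have more. Where it says the series, first, only, none or still open, it means among the compounds named here.

compound 1 `CCCC(=O)N(Cc1ccccc1)C1CCN(S(=O)(=O)c2c(C)cc(C)cc2C)CC1`: only a limit in a functional assay on DLD-1 cells (Homo sapiens) for antiproliferative activity, read by CellTiter-Glo, with a stated time of 72 h (on this read-out higher numbers stand for weaker inhibition and lower numbers for stronger inhibition), > 5000 nM the limit of > 5000 nM in this assay, at which 1 of the 3 values shown sits.
compound 2 `CCc1cc(Br)ccc1S(=O)(=O)N1CCC(N2CCC(C)CC2)CC1`: 0.6 nM
compound 3 `CC1CCN(C2CCN(S(=O)(=O)c3cccc(-c4ccccc4F)c3)CC2)CC1`: 10 nM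

Of the two numbers in this assay, compound 3 gives the higher one; compound 2 sits well below it, a gap beyond the scatter. Compound 4 `COc1cccc(S(=O)(=O)N2CCC(N3CCC(C)CC3)CC2)c1` is not yet measured. It differs from compound 3 in one place: methoxy in place of 2-fluorophenyl on an aromatic carbon. The 2-fluorophenyl leaves and a methoxy enters, on an aromatic carbon of a six-membered aromatic ring of carbon only, meta to a large group. Among the measured compounds shown here, no measured pair isolates this change, so the direction rests on the two numbers alone. The step of a 2.5-fold higher number from compound 3 to compound 4 (0.40 log units; beyond the scatter) is expected to be modest, toward a higher number, close to the scatter. Compound 4 is expected at 25 nM, between 4 nM and 150 nM.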

Compound 4, half-maximal inhibitory concentration: > 5000 nM
Compound 4 gave a limit, no number (the forecaster's own chance of this, stated with the estimate: 5%); at least 200-fold (2.30 log units) between middle value and limit.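

In this assay, among the compounds shown here, this aromatic carbon proves highly sensitive to what it carries: methoxy in place of 2-fluorophenyl gives an at least 500-fold higher number from compound 3 to compound 4 (2.69 log units; beyond the scatter), the first step that isolates a single change. Compound 4 gives only a limit, not a number: the limit of > 5000 nM in this assay, at which 2 of the 4 values shown sit.

The compounds shown leave open whether activity depends on the aromatic ring at this carbon or on its fluorine. Plain phenyl, a pyridine or a morpholine at the same carbon would separate these possibilities.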